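Compound 3: Changing the Sulfur-Linked Arm of a Weak Inhibitor

The compounds below may be only part of what the source reports. "The series", "measured", "known", "first", "only" and "open" are said of these compounds alone.

Compound 1 `COc1ccc(-n2c(SCc3ccccc3)nnc2-c2cc(OC)c(OC)c(OC)c2)cc1`: 42400 nM
Compound 2 `COc1cc(-c2nnc(SCc3ccccc3)n2-c2ccc(N(C)C)cc2)cc(OC)c1OC`: 54000 nM

Within the data shown here, in a functional assay on HCT-116 cells (Homo sapiens) for inhibition, read by MTT assay, with a stated time of 48 h (a higher number here means a weaker inhibitor, a lower number a stronger inhibitor), compound 2 has the highest of the two numbers, with compound 1 nearest; the single step of a 1.3-fold higher number from compound 1 to compound 2 (0.11 log units; within the scatter) is within the scatter, so the two are not distinguishable. Compound 3 `COc1ccc(C(=O)CSc2nnc(-c3cc(OC)c(OC)c(OC)c3)n2-c2ccc(N(C)C)cc2)cc1` differs from compound 2 by (4-methoxyphenyl)carbonyl in place of phenyl on a saturated chain carbon bound to a sulfur. Among the measured compounds shown here, the only measured step concerns the dimethylamino and methoxy groups, not the sulfur-linked arm, so no measured step bears on this change. No movement beyond the scatter is therefore expected: compound 3 is estimated at 45000 nM (range 12000 nM to 150000 nM), a step of a 1.2-fold lower number from compound 2 to compound 3 (0.08 log units; within the scatter).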

Compound 3, half-maximal inhibitory concentration: > 60000 nM
Compound 3: only a limit was reported (the forecaster's own chance of this, stated with the estimate: 15%); middle value at least 1.3-fold (0.12 log units) from the limit.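

Among these compounds, the sulfur-linked arm changes here for the first time, and replacing phenyl with (4-methoxyphenyl)carbonyl on a saturated chain carbon bound to a sulfur gives an at least 1.1-fold higher number from compound 2 to compound 3 (0.04 log units; that floor lies within the scatter) in this assay. So this change brings no visible gain in inhibition, though the true size of the step stays unknown. Compound 3 has only a limit of the assay, not a number: the limit of > 60000 nM in this assay, at which 1 of the 3 values shown sits.

The compounds shown do not separate the carbonyl from the methoxy group in this change. On these data alone, whether a carboxylic acid or an amine on this arm would give a stronger inhibitor also remains open.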